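Swapping Bromo for Pentyl on a Weakly Active Scaffold

The compounds below may be only part of what the source reports. "The series", "measured", "known", "first", "only" and "open" are said of these compounds alone.

Compound 3 `O=c1cc(Cn2cc(-c3ccc(Br)cc3)nn2)c2ccc(O)cc2o1` is the only one of the three measured compounds to give a number at all: in a functional assay on SW-620 cells (Homo sapiens) for inhibition, read by MTT assay, with a stated time of 72 h (on this read-out higher numbers stand for weaker inhibition and lower numbers for stronger inhibition), compound 3 gives 97700 nM. Compound 1 `O=c1cc(Cn2cc(CCCO)nn2)c2ccc(O)cc2o1` reaches only a limit of the assay, giving > 100000 nM in this assay. Compound 2 `O=c1cc(Cn2cc(CCCCO)nn2)c2ccc(O)cc2o1` likewise stops at a limit, giving > 100000 nM. Two of the three values therefore sit at the limit of > 100000 nM in this assay, at which 2 of the 3 values shown sit, and what separates compound 3 from them is slight: an at least 1.0-fold lower number from compound 1 to compound 3 (0.01 log units; that floor lies within the scatter) and an at least 1.0-fold lower number from compound 2 to compound 3 (0.01 log units; that floor lies within the scatter), while a step that the two limits leave unreadable from compound 1 to compound 2.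

Compound 4 `CCCCCc1ccc(-c2cn(Cc3cc(=O)oc4cc(O)ccc34)nn2)cc1` differs from compound 3 by pentyl in place of bromo on an aromatic carbon. Within the data shown here, none of the measured steps touches this position; the two readable steps alter the group on the aromatic carbon of the shared core, not a substituent on the 4-bromophenyl ring, and both were no larger than the scatter allows. The pentyl group brings five carbon atoms and no donors or acceptors where bromo brought a single bromine, but there is no measured evidence on what that exchange does here.

The expected change from compound 3 to compound 4 in this assay is therefore small, a 1.6-fold lower number from compound 3 to compound 4 (0.21 log units; within the scatter), with a real chance that compound 4 also ends at a limit. Compound 4 is estimated at 60000 nM, with a range from 15000 nM to 150000 nM.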

Compound 4, half-maximal inhibitory concentration: 39600 nM
Compound 4: the middle estimate sits 1.5-fold (0.18 log units) above what was measured; the range from low to high includes it.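

On the aromatic carbon para to a large group, the substituent makes a difference in this assay: pentyl in place of bromo gives a 2.5-fold lower number from compound 3 to compound 4 (0.39 log units; beyond the scatter). This is the only step among the compounds shown that is both readable in size and beyond the scatter, and it is the only one to change a substituent on this ring rather than the whole group on the shared core. The step is modest, however, and the earlier steps offer no comparison of its size, as their limits leave them unreadable: the limit of > 100000 nM in this assay, at which 2 of the 4 values shown sit.

With only bromo and pentyl at this position, the compounds shown leave open whether the lower number goes with the chain itself, with its length, or simply with the absence of bromine. A plain hydrogen, a shorter chain such as propyl, a longer chain such as octyl, or an amine or a carboxylic acid at the same carbon would be needed to tell these readings apart.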